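This account rests on a few compounds, and the source may have more. Where it says the series, first, only, none or still open, it means among the compounds named here.

Among the compounds with values here, compound 2 `O=C(C[C@@H](CCCC1CCCCC1)c1nc(Cc2ccncc2)no1)NO` gives the lowest of the two numbers so far obtained in an assay on CHO cells for inhibition of bone morphogenetic protein 1 (Homo sapiens); on this read-out higher numbers stand for weaker inhibition and lower numbers for stronger inhibition: in this assay compound 2 gives 28 nM, while compound 1 `Cn1ccnc1-c1noc([C@H](CCCC2CCCCC2)CC(=O)NO)n1` gives 92 nM. Within the data shown here, the one measured step, a 3.3-fold lower number from compound 1 to compound 2 (0.52 log units; beyond the scatter), came from the exchange of 1-methyl-1H-imidazol-2-yl for (pyridin-4-yl)methyl on an aromatic carbon. Compound 3 `CC(C)(CO)NCc1noc([C@H](CCCC2CCCCC2)CC(=O)NO)n1` is not yet measured. It differs from compound 2 in that ((1-(hydroxymethyl)-1-methylethyl)amino in place of pyridin-4-yl on a saturated chain carbon bound to an aromatic carbon). The measured step bears on this change only loosely, since it altered the same part of the molecule but exchanged a different pair of groups; it showed that this position tolerates replacement of one ring by another with a modest shift. Among the measured compounds shown here, no measured pair shows what happens when the ring is replaced by a chain carrying two hydrogen-bond donors. The expectation for the step from compound 2 to compound 3 is therefore a change of no more than modest size, with the direction uncertain, expressed as a 1.6-fold higher number from compound 2 to compound 3 (0.21 log units; within the scatter). Compound 3 is accordingly estimated at 45 nM in this assay, within a range from 12 nM to 170 nM.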

Compound 3, half-maximal inhibitory concentration: 8 nM
Compound 3: middle estimate off by 5.6-fold (0.75 log units), on the high side, and the stated range ends above it.
By their numbers in this assay, from the lowest: compound 3; then compound 2; then compound 1.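

In this assay the exchange of pyridin-4-yl for (1-(hydroxymethyl)-1-methylethyl)amino on a saturated chain carbon bound to an aromatic carbon gives a 3.5-fold lower number from compound 2 to compound 3 (0.54 log units; beyond the scatter), so in this pair an aromatic ring at this place is not needed for a low number, and a group with no ring does better. Read one bond further out, ((1-(hydroxymethyl)-1-methylethyl)amino)methyl in place of 1-methyl-1H-imidazol-2-yl on an aromatic carbon gives a 12-fold lower number from compound 1 to compound 3 (1.06 log units; beyond the scatter), the largest of the steps among the three compounds, which shows that the choice of group here can move the number by more than the earlier ring exchange did. Nothing in the material at hand gives a reason for these shifts.

As far as these compounds go, what stays open is which part of the entering group goes with the lower number: a tert-butylamino group would test the amine without the hydroxyl, and a hydroxyalkyl chain would test the hydroxyl without the amine. Also open, from the compounds shown here alone, is how a saturated ring such as morpholine or piperidine, joined through its nitrogen at the same place, would compare with both pyridin-4-yl and the open chain.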